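The compounds below may be only part of what the source reports. "The series", "measured", "known", "first", "only" and "open" are said of these compounds alone.

Measured in a functional assay on A549 cells (Homo sapiens) for cytotoxicity, read by resazurin assay, with a stated time of 72 h; on this read-out lower numbers stand for stronger inhibition and higher numbers for weaker inhibition:
compound 1 `N#Cc1cc(-c2ccccc2)n(-c2nc3ccccc3[nH]2)c1N`: 12100 nM
compound 2 `Nc1c(-c2nc3ccccc3[nH]2)cc(-c2ccccc2)n1-c1ccncc1`: 1100 nM
compound 3 `Nc1c(-c2nc3ccccc3[nH]2)cc(-c2ccccc2)n1-c1ccc(Cl)cc1`: 9900 nM

Compound 3 lies within the scatter of compound 1 and well above compound 2. Next is compound 4 `Nc1c(-c2nc3ccccc3[nH]2)cc(-c2ccccc2)n1-c1nc2ccccc2[nH]1`, with 1H-benzimidazol-2-yl in place of 4-chlorophenyl on an aromatic nitrogen. For the measured compounds named here, the one measured step at this nitrogen is a 9.0-fold higher number from compound 2 to compound 3 (0.95 log units; beyond the scatter), which is modest. Compound 4 has its second 1H-benzimidazol-2-yl where compound 1 has a nitrile. Compound 1 already carries 1H-benzimidazol-2-yl on that nitrogen and gives 12100 nM. A smaller step than the modest one is therefore expected in this assay, slightly downward, possibly none beyond the scatter. The estimate amounts to a 1.7-fold lower number from compound 3 to compound 4 (0.22 log units; within the scatter). The expected value for compound 4 is 6000 nM, within 1500 nM to 20000 nM.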

Compound 4, half-maximal inhibitory concentration: 7700 nM
The estimate for compound 4 lay 1.3-fold (0.11 log units) below the measured number, and the stated range covers the measured number.
By their numbers in this assay, from the lowest: compound 2; then compounds 4, 3 and 1 (each within the scatter of the next).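

In this assay, 1H-benzimidazol-2-yl on the aromatic nitrogen cannot be told apart from 4-chlorophenyl (a 1.3-fold lower number from compound 3 to compound 4 (0.11 log units; within the scatter)), whereas the gap to pyridin-4-yl remains (a 7.0-fold higher number from compound 2 to compound 4 (0.85 log units; beyond the scatter)), so among these three groups only pyridin-4-yl stands apart. At the aromatic carbon, a second 1H-benzimidazol-2-yl in place of the nitrile also stays within the scatter (a 1.6-fold lower number from compound 1 to compound 4 (0.20 log units; within the scatter)). Nothing at hand explains why pyridin-4-yl stands apart. Open, from the compounds shown here alone, is whether pyridin-3-yl, or a phenyl ring carrying an amine or a carboxylic acid, on this nitrogen would keep the number of compound 2 (1100 nM).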